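Amino in place of nitro on compound 1

The compounds below may be only part of what the source reports. "The series", "measured", "known", "first", "only" and "open" are said of these compounds alone.

In an ADME assay on HeLa cells (Homo sapiens) for cytotoxicity, read by crystal violet staining, with a stated time of 72 h (on this read-out lower numbers stand for higher toxicity in this test and higher numbers for lower toxicity in this test), compound 1 (`CCOC(=O)c1cc(CCCOc2ccc(-c3noc(C(F)(F)F)n3)cc2[N+](=O)[O-])on1`) gives > 100000 nM as its reading, which is a limit of the assay and not a number. Compound 1 thus stands at the limit of > 100000 nM in this assay, at which 2 of the 3 values shown sit, and has no exact place on the scale. Compound 2 (`CCOC(=O)c1cc(CCCOc2c(OC)cc(-c3noc(C(F)(F)F)n3)cc2[N+](=O)[O-])on1`) gives > 100000 nM as its reading, again a limit. Methoxy in place of hydrogen on an aromatic carbon gives a step that the two limits leave unreadable from compound 1 to compound 2 as the outcome. Within the data shown here, compound 3 (`CN(C)C(=O)c1cc(CCCOc2ccc(-c3noc(C(F)(F)F)n3)cc2[N+](=O)[O-])on1`) reads 22500 nM in this assay as the only exact number so far. Compound 4 (`CCOC(=O)c1cc(CCCOc2ccc(-c3noc(C(F)(F)F)n3)cc2N)on1`) carries amino in place of nitro on an aromatic carbon and has not yet been measured. Neither measured step touches that group, so both bear on it only loosely. Among the measured compounds shown here, the expectation rests on compound 3, where dimethylamino in place of ethoxy on a carbonyl carbon gives an at least 4.4-fold lower number from compound 1 to compound 3 (0.64 log units; beyond the scatter) as the only readable step. A modest move towards a lower number in this assay is therefore expected, though a reading at the limit remains likely. The estimated change is an at least 1.4-fold lower number from compound 1 to compound 4 (0.15 log units; that floor lies within the scatter) in size. For compound 4 the estimated value is 70000 nM with an expected range from 20000 nM to 200000 nM in this test.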

Compound 4, half-maximal cytotoxic concentration: > 100000 nM
Compound 4 gave a limit, no number (the forecaster's own chance of this, stated with the estimate: 50%); middle value at least 1.4-fold (0.15 log units) away from the limit.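

Compound 4, like compound 1, reads as a limit and not a number in this assay, so no new step can be read between compound 1 and compound 4: the limit of > 100000 nM in this assay, at which 3 of the 4 values shown sit.

The compounds shown leave open whether amino in place of nitro on an aromatic carbon changes the reading at all.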